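The source may report more compounds than this note shows. Statements on the series, on what has been measured and on what is new or still open speak of the compounds shown alone.

Values in an ADME assay on SH-SY5Y cells (Homo sapiens) for cytotoxicity, read by MTT assay, with a stated time of 72 h; a higher number here means a weaker inhibitor, a lower number a stronger inhibitor:
- Compound 1 `O=C(CN1CCN(C(=O)c2ccccc2)CC1)N1CCN(CCCc2c[nH]c3ccccc23)CC1`: > 200000 nM, a limit of the assay and not a number.
- Compound 2 `O=C(CN1CCN(C(=O)c2ccc(Cl)cc2)CC1)N1CCN(CCCc2c[nH]c3ccccc23)CC1`: 139000 nM
- Compound 3 `O=C(CN1CCN(C(=O)c2cccc(Cl)c2)CC1)N1CCN(CCCc2c[nH]c3ccccc23)CC1`: 120000 nM

Within the data shown here, only two compounds carry true numbers, and they are separated by a 1.2-fold lower number from compound 2 to compound 3 (0.06 log units; within the scatter).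

Compound 4 `O=C(CN1CCN(C(=O)c2cccc(F)c2)CC1)N1CCN(CCCc2c[nH]c3ccccc23)CC1` carries fluoro in place of the chloro of compound 3: fluoro in place of chloro on an aromatic carbon. Among the measured compounds shown here, no measured step makes this exchange. The nearest are an at least 1.4-fold lower number from compound 1 to compound 2 (0.15 log units; that floor lies within the scatter) and an at least 1.6-fold lower number from compound 1 to compound 3 (0.22 log units; that floor lies within the scatter), both floors set by the limit of > 200000 nM in this assay, at which 1 of the 3 values shown sits. No shift beyond the scatter is therefore expected in this assay. The expected step is a 1.3-fold higher number from compound 3 to compound 4 (0.10 log units; within the scatter). Compound 4 is estimated at 150000 nM, with an expected range of 95000 nM to 240000 nM.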

Compound 4, half-maximal inhibitory concentration: 165000 nM
Beside the measured number, compound 4's estimate is 1.1-fold (0.04 log units) below it; measured number inside the range.
By their numbers in this assay, from the lowest: compounds 3, 2 and 4 (each within the scatter of the next). At a limit, above all of these: compound 1.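

Fluoro in place of chloro on this aromatic carbon, meta to a large group, gives a 1.4-fold higher number from compound 3 to compound 4 (0.14 log units; within the scatter), so in this assay the exchange of one halogen for the other does not separate the two compounds. The step between the 3-fluorophenyl and 4-chlorophenyl compounds is a 1.2-fold higher number from compound 2 to compound 4 (0.07 log units; within the scatter), which leaves compounds 2, 3 and 4 all within the scatter of one another. Compound 1 stands at a limit of the assay, so fluoro in place of hydrogen reads only as an at least 1.2-fold lower number from compound 1 to compound 4 (0.08 log units; that floor lies within the scatter): the limit of > 200000 nM in this assay, at which 1 of the 4 values shown sits.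

As far as these compounds go, the true size of any step from hydrogen to halogen remains open. Also open, from the compounds shown here alone, is whether a methoxy, a nitrile or an amine on this carbon would give a step beyond the scatter.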